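From anilino to morpholin-4-yl: an unmeasured step

This account rests on a few compounds, and the source may have more. Where it says the series, first, only, none or still open, it means among the compounds named here.

Going by the values given here, in a functional assay on SMMC-7721 cells (Homo sapiens) for antiproliferative activity, read by MTT assay, with a stated time of 72 h (on this read-out higher numbers stand for weaker inhibition and lower numbers for stronger inhibition), compound 2 `C/C(=N\NC(=S)Nc1ccccc1)c1cc(Cl)ccc1O` gives 19200 nM, the only exact number so far. Compound 3 `C/C(=N\NC(=S)N1CCOCC1)c1cc(Cl)ccc1O` carries morpholin-4-yl in place of anilino on a thiocarbonyl carbon. Among the compounds with values here, no measured pair shows this change on its own. Compound 1 `C/C(=N\NC(=S)N1CCOCC1)c1ccccc1O` also carries morpholin-4-yl and gives > 64000 nM, which is a limit of the assay and not a number. On that basis, a moderate step towards weaker inhibition is expected, estimated as a 2.1-fold higher number from compound 2 to compound 3 (0.32 log units; beyond the scatter). Compound 3 is expected to give about 40000 nM, with an estimated range from 15000 nM to 100000 nM.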

Compound 3, half-maximal inhibitory concentration: > 64000 nM
Compound 3 gave a limit, no number; the forecaster's own chance of this, stated with the estimate: 40%; middle value at least 1.6-fold (0.20 log units) away from the limit.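

In this assay, the change of anilino to morpholin-4-yl on a thiocarbonyl carbon can now be read on its own, and it gives an at least 3.3-fold higher number from compound 2 to compound 3 (0.52 log units; beyond the scatter). So at this position, on the chloro-bearing core, anilino is the better of the two groups, though the true size of the step stays hidden behind a limit. The step for chloro in place of hydrogen on an aromatic carbon cannot be read, because the values of both compounds end at the same point: the limit of > 64000 nM in this assay, at which 2 of the 3 values shown sit.

Still open, as far as these compounds go, is how a piperidin-1-yl ring or a dimethylamino group would behave on the same thiocarbonyl carbon. From the compounds shown here alone, whether either would sit closer to anilino or to morpholin-4-yl remains unknown.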